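A Phenyl Group in Place of 3-Cyanobenzyl

A few compounds are considered here, and "the series" means these few. Any claim that something is new, unique, unknown or untested is made for them only; others in the source may bear on it.

Measured so far in an in vitro functional assay on cells for agonist activity at Bombesin receptor subtype-3 (Mus musculus), read by luminescence and calcium flux; a higher number here means that more compound is needed for the effect, a lower number that less compound is needed:
- compound 1 `O=C(O)c1ccccc1-c1ccc(CCc2ncc(CC3CCC3)[nH]2)cc1` gives 7.1 nM
- compound 2 `COc1ccc(Cc2cnc(CCc3ccc(-c4ccccc4C(=O)O)cc3)[nH]2)cc1` gives 513 nM
- compound 3 `N#Cc1cccc(Cc2cnc(CCc3ccc(-c4ccccc4C(=O)O)cc3)[nH]2)c1` gives 20 nM

Compound 3 stands second highest of these three numbers in this assay: compound 1 sits below it, shown by a 2.8-fold higher number from compound 1 to compound 3 (0.45 log units; beyond the scatter), while compound 2 sits far above it, shown by a 26-fold lower number from compound 2 to compound 3 (1.41 log units; beyond the scatter).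

Compound 4 `O=C(O)c1ccccc1-c1ccc(CCc2ncc(-c3ccccc3)[nH]2)cc1` differs from compound 3 by phenyl in place of 3-cyanobenzyl on an aromatic carbon. All three measured steps change the group on the saturated chain carbon, and they show this region is sensitive: a 72-fold higher number from compound 1 to compound 2 (1.86 log units; beyond the scatter), yet the smaller move a 2.8-fold higher number from compound 1 to compound 3 (0.45 log units; beyond the scatter). Going by the values given here, none of them removes the chain carbon itself, so no step matches the present change directly. Given that sensitivity, a modest weakening is expected, about a 3.0-fold higher number from compound 3 to compound 4 (0.48 log units; beyond the scatter). Compound 4 is therefore estimated at 60 nM, with a range from 10 nM to 400 nM.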

Compound 4, half-maximal effective concentration: 872 nM
For compound 4 the middle estimate is 15-fold (1.16 log units) below the measured one, and the stated range ends below it.
By their numbers in this assay, from the lowest: compound 1; then compound 3; then compounds 2 and 4 (each within the scatter of the next).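

With phenyl directly on the aromatic carbon, the low number of compound 3 does not survive (a 44-fold higher number from compound 3 to compound 4 (1.64 log units; beyond the scatter)), and the distance from the cyclobutylmethyl compound is greater still (a 120-fold higher number from compound 1 to compound 4 (2.09 log units; beyond the scatter)). Compound 4 instead falls within the scatter of the 4-methoxybenzyl compound (a 1.7-fold higher number from compound 2 to compound 4 (0.23 log units; within the scatter)), so this position tolerates losing the 3-cyanobenzyl group poorly. No measurement here explains this.

This change removes the chain carbon and the nitrile together, and the compounds shown cannot separate the two. Unsubstituted benzyl, or a phenyl carrying a nitrile, would pull them apart.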